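A few compounds are considered here, and "the series" means these few. Any claim that something is new, unique, unknown or untested is made for them only; others in the source may bear on it.

Compound 3 `CC(=O)c1ccc(-c2sc(N)c(C(=O)c3ccccc3)c2-c2cccc(C(F)(F)F)c2)cc1` stands at a limit of the assay: in a functional assay on CHO-K1 cells for agonist activity at adenosine receptor A1 (Homo sapiens), read by GTPgammaS binding (a lower number here means that less compound is needed, a higher number that more compound is needed for the effect), compound 3 gives > 10 uM, which is a limit rather than a number. Compound 1 `Nc1sc(Br)c(-c2cccc(C(F)(F)F)c2)c1C(=O)c1ccccc1` also sits at a limit, giving > 10 uM in this assay. Compound 2 `Nc1sc(-c2ccccc2)c(-c2cccc(C(F)(F)F)c2)c1C(=O)c1ccccc1` gives a real number, 2.3 uM in this assay. Two of the three values therefore sit at the limit of > 10 uM in this assay, at which 2 of the 3 values shown sit. Compound 4 `Nc1sc(-c2ccc(Cl)cc2)c(-c2cccc(C(F)(F)F)c2)c1C(=O)c1ccccc1` differs from compound 3 by one change: chloro in place of acetyl on an aromatic carbon. For the measured compounds named here, two measured steps bear on this. The step of an at least 4.3-fold higher number from compound 2 to compound 3 (0.63 log units; beyond the scatter) shows that adding the acetyl pushed the value out to the limit, and the step of an at least 4.3-fold lower number from compound 1 to compound 2 (0.63 log units; beyond the scatter) shows that the phenyl ring itself lowers the number. The step that the two limits leave unreadable from compound 1 to compound 3 adds nothing readable. Removing the acetyl is thus expected to bring the value back toward that of compound 2, with the chloro taken as a small departure from hydrogen. Compound 4 is accordingly expected at 3 uM in this assay, within a range from 1 uM to 10 uM. This amounts to an expected at least 3.3-fold lower number from compound 3 to compound 4 (0.52 log units; beyond the scatter).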

Compound 4, concentration for half-maximal effect: > 10 uM
Compound 4: only a limit was reported (the forecaster's own chance of this, stated with the estimate: 25%); middle value at least 3.3-fold (0.52 log units) from the limit.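

In this assay compound 4 gives > 10 uM, which is a limit of the assay and not a number. Chloro in place of hydrogen on the phenyl ring gives an at least 4.3-fold higher number from compound 2 to compound 4 (0.63 log units; beyond the scatter), so the rise seen with acetyl at this place, para to a large group, is not confined to acetyl: of the three phenyl-bearing compounds, only the one with hydrogen here has a real number. The steps to compound 4 from compound 1 and from compound 3 cannot be read, since both ends of each are limits, and the values now crowd at one edge: the limit of > 10 uM in this assay, at which 3 of the 4 values shown sit.

From the compounds shown here alone, how far compound 1, compound 3 and compound 4 lie beyond that limit stays unknown, so chloro and acetyl cannot be ranked. Also open, going by these compounds, is whether a fluoro, a methyl or an amine at this place would give a real number, and how it would compare with compound 2.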